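The compounds below may be only part of what the source reports. "The series", "measured", "known", "first", "only" and "open" are said of these compounds alone.

Measured compounds:
Compound 1, `C[S+]([O-])/C=C/c1cc(=O)c2cc(C#N)ccc2o1`: in a functional assay on DLD-1 cells (Homo sapiens) for cytotoxicity, with a stated time of 48 h (a lower number here means a stronger inhibitor, a higher number a weaker inhibitor), compound 1 gives > 10000 nM, which is a limit of the assay.
Compound 2, `CCCC(=O)Oc1ccc2oc(/C=C/[S+](C)[O-])cc(=O)c2c1`: in this assay compound 2 gives 8700 nM.
Compound 3, `CC(=O)Oc1ccc2oc(/C=C/[S+](C)[O-])cc(=O)c2c1`: in this assay compound 3 gives > 10000 nM, which is a limit of the assay.

Compound 3 therefore stands at the limit rather than at a number, and it is one of the two values that sit there (the limit of > 10000 nM in this assay, at which 2 of the 3 values shown sit). Compound 4 is `CC(C)CC(=O)Oc1ccc2oc(/C=C/[S+](C)[O-])cc(=O)c2c1` and differs from compound 3 by isopropyl in place of hydrogen on a saturated chain carbon bound to a carbonyl carbon. The measured step that bears on this change is an at least 1.1-fold higher number from compound 2 to compound 3 (0.06 log units; that floor lies within the scatter), which runs at the same place but in the opposite sense, replacing a chain by hydrogen; read backwards it suggests that a chain entering here gives a lower number, though only by a floor that lies within the scatter. The steps of an at least 1.1-fold lower number from compound 1 to compound 2 (0.06 log units; that floor lies within the scatter) and a step that the two limits leave unreadable from compound 1 to compound 3 concern another position and add little. The two limits the limit of > 10000 nM in this assay, at which 2 of the 3 values shown sit, leave the true size of any step unreadable. A modest lowering, possibly within the scatter, is thus expected. Compound 4 is expected to give about 7500 nM, between 3000 nM and 20000 nM. The expected step is an at least 1.3-fold lower number from compound 3 to compound 4 (0.12 log units; that floor lies within the scatter).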

Compound 4, half-maximal inhibitory concentration: 6100 nM
Estimate against measurement, compound 4: 1.2-fold (0.09 log units) above; measured number inside the range.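

The isobutylcarbonyl ester gives this position a second measured number in this assay, so two esters on the shared core can now be compared directly: the result is a 1.4-fold lower number from compound 2 to compound 4 (0.15 log units; within the scatter), which sets no order between the two chains. Against the acetoxy compound the change reads an at least 1.6-fold lower number from compound 3 to compound 4 (0.21 log units; that floor lies within the scatter), and against the cyano compound it reads an at least 1.6-fold lower number from compound 1 to compound 4 (0.21 log units; that floor lies within the scatter); both are floors only, and neither floor clears the scatter. The true size of these two steps stays unreadable because compound 1 and compound 3 each stand at a limit: the limit of > 10000 nM in this assay, at which 2 of the 4 values shown sit.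

Going by these compounds, whether a longer chain on the ester, or a benzoyl group in its place, would move the number beyond the scatter remains open. Also open, on these data alone, is what a chain ending in an amine or a carboxylic acid would give here.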